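Methyl in place of chloro: what to expect

The compounds below may be only part of what the source reports. "The series", "measured", "known", "first", "only" and "open" are said of these compounds alone.

In an ADME assay on HEK-293T cells (Homo sapiens) for inhibition, read by CCK-8 assay, with a stated time of 48 h, tested at 20 uM (a lower number here means less inhibition of growth, a higher number more inhibition of growth at the concentration tested), compound 1 (`N#C/C(=C\c1ccccc1OS(=O)(=O)c1ccc(Cl)cc1)C(=O)Nc1nnc(Cc2cccc3ccccc23)s1`) gives 16% and compound 2 (`N#C/C(=C\c1ccccc1OS(=O)(=O)c1ccc(Cl)cc1)C(=O)Nc1nnc(Cc2ccc(Cl)cc2)s1`) gives 14% within the usual scatter of compound 1. The two therefore cannot be ranked, and compound 2 simply sits at this low level of growth inhibition. The next compound to be tested, compound 3 (`Cc1ccc(Cc2nnc(NC(=O)/C(C#N)=C/c3ccccc3OS(=O)(=O)c3ccc(Cl)cc3)s2)cc1`), carries methyl in place of chloro on an aromatic carbon, so that 4-chlorobenzyl becomes 4-methylbenzyl (methyl in place of chloro on an aromatic carbon). Within the data shown here, the only measured step that bears on this is a number 2 percentage points lower from compound 1 to compound 2 (within the scatter) for 4-chlorophenyl in place of naphthalen-1-yl, and it lies within the scatter. Among the measured compounds shown here, no measured compound carries the methyl, so this evidence is thin. The expected result in this assay is a number 1 percentage points higher from compound 2 to compound 3 (within the scatter) and no step beyond the scatter. The estimate for compound 3 is 15% with 4% to 28% as the expected range.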

Compound 3, percent growth inhibition at one concentration: 8%
For compound 3 the middle estimate is 7 percentage points above the measured one; low and high end bracket the measured number.
By their numbers in this assay, from the lowest: compounds 3, 2 and 1 (each within the scatter of the next).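

In this assay, methyl in place of chloro on an aromatic carbon, para to a large group, gives a number 6 percentage points lower from compound 2 to compound 3 (within the scatter) and so adds a carbon group to the halogen already seen at this position, without separating the two. Going from the larger naphthalen-1-yl group to 4-methylphenyl gives a number 8 percentage points lower from compound 1 to compound 3 (within the scatter) and shows that all three groups tried on this saturated chain carbon lie within the scatter of one another. No measurement shown here offers an explanation for these small differences.

From the compounds shown here alone, it remains open whether an amine or a carboxylic acid at the same aromatic carbon would give a step beyond the scatter. A longer chain in place of the methyl is equally untested among the compounds shown, so the tolerance seen here extends only to these three groups.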